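The source may report more compounds than this note shows. Statements on the series, on what has been measured and on what is new or still open speak of the compounds shown alone.

Compound 1, `O=C(CN1CCC(c2cccc[n+]2[O-])CC1)NC1CCCCC1`, gives 294 nM in a functional assay on HEK293 cells for agonist activity at D(4) dopamine receptor (Homo sapiens), read by FLIPR; on this read-out higher numbers stand for an effect only at larger amounts of compound and lower numbers for an effect already at smaller amounts.
Compound 2, `O=C(CN1CCC(c2cccc[n+]2[O-])CC1)Nc1cc(Cl)cc(Cl)c1`, gives 160 nM in this assay.
Compound 3, `Cc1cc(Br)ccc1NC(=O)CN1CCC(c2cccc[n+]2[O-])CC1`, gives 66 nM in this assay.

Compound 3 stands at the lowest number of the three; both a 2.4-fold lower number from compound 2 to compound 3 (0.38 log units; beyond the scatter) and a 4.5-fold lower number from compound 1 to compound 3 (0.65 log units; beyond the scatter) lie beyond the scatter, so it is the most potent of the measured set. Compound 4, `Cc1cc(F)ccc1NC(=O)CN1CCC(c2cccc[n+]2[O-])CC1`, differs from it by fluoro in place of bromo on an aromatic carbon; read one bond further out, the change is 4-bromo-2-methylphenyl to 4-fluoro-2-methylphenyl. Within the data shown here, no measured step exchanges one halogen for another on the same ring: a 1.8-fold lower number from compound 1 to compound 2 (0.26 log units; within the scatter), a 4.5-fold lower number from compound 1 to compound 3 (0.65 log units; beyond the scatter) and a 2.4-fold lower number from compound 2 to compound 3 (0.38 log units; beyond the scatter) each replace the whole group on the amide-type nitrogen, so there is no direct precedent. Compound 4 is therefore expected near compound 3, with a small upward drift, estimated at 120 nM within 50 nM to 300 nM. That step, a 1.8-fold higher number from compound 3 to compound 4 (0.26 log units; within the scatter), is expected to remain close to the scatter.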

Compound 4, half-maximal effective concentration: 60 nM
Beside the measured number, compound 4's estimate is 2.0-fold (0.30 log units) above it; the range from low to high includes it.
By their numbers in this assay, from the lowest: compounds 4 and 3 (each within the scatter of the next); then compounds 2 and 1 (each within the scatter of the next).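

On the aromatic carbon para to a large group, fluoro in place of bromo leaves no readable difference in this assay (a 1.1-fold lower number from compound 3 to compound 4 (0.04 log units; within the scatter)), so at this position the two halogens cannot be told apart. The 4-fluoro-2-methylphenyl group also stands clear of the other two groups on the amide-type nitrogen, with (a 2.7-fold lower number from compound 2 to compound 4 (0.43 log units; beyond the scatter)) and (a 4.9-fold lower number from compound 1 to compound 4 (0.69 log units; beyond the scatter)). Nothing available gives a reason for these results. As far as these compounds go, whether an amine or a methoxy group on that carbon would give a similar number in this assay stays open, as does the contribution of the methyl group.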